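Adding a methyl group to compound 3

The source may hold more compounds than are shown below. What is called first, only, known or untested is meant among the compounds shown, and "the series" means these compounds.

In an ADME assay on RAW264.7 cells (Mus musculus) for cytotoxicity, read by MTT assay, with a stated time of 48 h (a higher number here means that more compound is tolerated, a lower number that less compound is tolerated), compound 1 `COc1ccc(NC(=S)N/N=C\c2ccnc3ccccc23)cc1` gives 101000 nM and compound 2 `S=C(N/N=C\c1ccnc2ccccc12)Nc1cccnc1` gives 91600 nM while compound 3 `S=C(N/N=C\c1ccnc2ccccc12)Nc1ccccc1` gives 118000 nM on the same scale. These numbers leave compound 3 within the usual scatter of both others, so the three cannot be ranked.

The next compound, compound 4 `Cc1ccc(NC(=S)N/N=C\c2ccnc3ccccc23)cc1`, carries methyl in place of hydrogen on an aromatic carbon, para to a large group (methyl in place of hydrogen on an aromatic carbon). Among the measured compounds shown here, no measured compound carries a methyl group. The nearest evidence comes from two other exchanges: hydrogen in place of methoxy on an aromatic carbon (a 1.2-fold higher number from compound 1 to compound 3 (0.07 log units; within the scatter)) and phenyl in place of pyridin-3-yl on an amide-type nitrogen (a 1.3-fold higher number from compound 2 to compound 3 (0.11 log units; within the scatter)). Both steps are small and lie within the scatter, so in this assay no step beyond the scatter is expected, and neither direction is favoured. The estimated step is a 1.1-fold lower number from compound 3 to compound 4 (0.05 log units; within the scatter) and no larger. For compound 4 the estimate is 105000 nM as the expected value, with an expected range from 60000 nM to 180000 nM around it.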

Compound 4, half-maximal cytotoxic concentration: 50500 nM
Compound 4: the middle estimate sits 2.1-fold (0.32 log units) above what was measured, outside the stated range (below it).
By their numbers in this assay, from the lowest: compounds 4, 2, 1 and 3 (each within the scatter of the next, the first and the last beyond it).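

In this assay, among the compounds shown here, a single methyl on an aromatic carbon, para to a large group, gives the only step in this set that passes the usual scatter (a 2.3-fold lower number from compound 3 to compound 4 (0.37 log units; beyond the scatter)), so even one added carbon at this position can mean that less compound is tolerated. Methyl in place of methoxy (a 2.0-fold lower number from compound 1 to compound 4 (0.30 log units; within the scatter)) and 4-methylphenyl in place of pyridin-3-yl (a 1.8-fold lower number from compound 2 to compound 4 (0.26 log units; within the scatter)) both stay within the scatter, so the change stands out only against the plain phenyl of compound 3. Nothing measured here offers a reason for this step.

As far as these compounds go, it remains open whether a longer chain such as ethyl, an amine or a carboxylic acid at this carbon would move the number as methyl does. From the compounds shown here alone, it also remains open whether methyl elsewhere on this ring would give a step of similar size.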